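Swapping Cyclopropyloxycarbonyl for a Trifluoromethyl Oxadiazole

The compounds below may be only part of what the source reports. "The series", "measured", "known", "first", "only" and "open" are said of these compounds alone.

compound 1 `Cc1nc(C(=O)OC2CC2)c(N)c2c1C(=O)N(Cc1ccccc1)C2=O` gives 202000 nM
compound 2 `Cc1nc(C(=O)N(C)C)c(N)c2c1C(=O)N(Cc1ccccc1)C2=O` gives 172000 nM
compound 3 `Cc1nc(C(=O)NC#N)c(N)c2c1C(=O)N(Cc1ccccc1)C2=O` gives 185000 nM

These numbers come from a physicochemical assay for solubility, using the shake flask method, in simulated intestinal fluid, measured as kinetic solubility, with a stated time of 2 h, at 25 degrees C, at pH 6.5; a lower number here means a less soluble compound, a higher number a more soluble compound. Compound 1 stands level with compound 2 and compound 3, with no gap beyond the scatter. Compound 4 `Cc1nc(-c2nc(C(F)(F)F)no2)c(N)c2c1C(=O)N(Cc1ccccc1)C2=O` has not yet been measured. It carries 3-(trifluoromethyl)-1,2,4-oxadiazol-5-yl in place of cyclopropyloxycarbonyl on an aromatic carbon.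

Two measured steps start from compound 1: a 1.2-fold lower number from compound 1 to compound 2 (0.07 log units; within the scatter) and a 1.1-fold lower number from compound 1 to compound 3 (0.04 log units; within the scatter). A third links the other two: a 1.1-fold higher number from compound 2 to compound 3 (0.03 log units; within the scatter). All three are small, but each changes only the group on a carbonyl carbon and keeps that carbonyl. Among the measured compounds shown here, compound 4 loses that carbonyl and gains a five-membered aromatic ring, a kind of change that no measured compound covers. The small steps therefore give only weak guidance, and the data do not settle the direction. A moderately lower number is a cautious expectation, held with a wide margin. The expected change is a 1.8-fold lower number from compound 1 to compound 4 (0.26 log units; within the scatter). For compound 4 the estimated value is 110000 nM, with an expected range from 35000 nM to 220000 nM.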

Compound 4, solubility: < 5000 nM
Compound 4 was reported as a limit (the forecaster's own chance of this, stated with the estimate: 10%); middle value at least 22-fold (1.34 log units) away from the limit.
By their numbers in this assay, from the lowest: compounds 2, 3 and 1 (each within the scatter of the next). At a limit, below all of these: compound 4.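

Compound 4 sits at a limit of this assay, not at a number: the limit of < 5000 nM in this assay, at which 1 of the 4 values shown sits.

The earlier compounds shown here differ only in the group on a carbonyl carbon and stay within the scatter of one another, whereas placing 3-(trifluoromethyl)-1,2,4-oxadiazol-5-yl on this aromatic carbon, with no carbonyl left there, gives an at least 40-fold lower number from compound 1 to compound 4 (1.60 log units; beyond the scatter), an at least 37-fold lower number from compound 3 to compound 4 (1.56 log units; beyond the scatter) and an at least 34-fold lower number from compound 2 to compound 4 (1.53 log units; beyond the scatter). This position next to the ring nitrogen is therefore not indifferent to what it carries: the level picture holds only among the three groups that keep the carbonyl, and it ends with this five-membered aromatic ring in their place.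

The compounds shown do not separate the ring from the trifluoromethyl group it carries, and the same ring with a methyl group in place of trifluoromethyl would tell the two apart. They also leave open how far under its limit compound 4 lies, and where a carboxylic acid or a small amine on this aromatic carbon would fall.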